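The source may hold more compounds than are shown below. What is called first, only, known or untested is meant among the compounds shown, and "the series" means these compounds.

Compound 1 `N#C/C(=C\c1ccc[nH]1)C(=O)NCc1ccc(Cl)c(Cl)c1`: in a functional assay on A-431 cells (Homo sapiens) for inhibition, read by MTT assay, with a stated time of 72 h (on this read-out lower numbers stand for stronger inhibition of growth and higher numbers for weaker inhibition of growth), compound 1 gives > 50000 nM, which is a limit of the assay rather than a number.
Compound 2 `COc1ccc(CNC(=O)/C(C#N)=C/c2ccco2)cc1`: in this assay compound 2 gives 16000 nM.
Compound 3 `COc1ccc(CNC(=O)/C(C#N)=C/c2ccc(Cl)o2)cc1`: in this assay compound 3 gives 9000 nM.

Compound 1 therefore stands only at a limit, with no measured number, as shown by the limit of > 50000 nM in this assay, at which 1 of the 3 values shown sits. The step to compound 4 `N#C/C(=C\c1ccc(Cl)cc1)C(=O)NCc1ccc(Cl)c(Cl)c1` is 4-chlorophenyl in place of 1H-pyrrol-2-yl on a double-bonded chain carbon bound to a double-bonded chain carbon. For the measured compounds named here, the single measured step, a 1.8-fold lower number from compound 2 to compound 3 (0.25 log units; within the scatter), concerns a chloro substituent on a ring and lies within the scatter, so it offers no direct guide to exchanging one aromatic ring for another. The step of an at least 1.2-fold lower number from compound 1 to compound 4 (0.09 log units; that floor lies within the scatter) is expected to be uncertain, and a reading at the limit again seems quite possible. Compound 4 is estimated at 40000 nM, with a range from 8000 nM to 200000 nM.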

Compound 4, concentration for 50% growth inhibition: 30000 nM
The estimate for compound 4 lay 1.3-fold (0.12 log units) above the measured number, and the stated range covers the measured number.
By their numbers in this assay, from the lowest: compounds 3, 2 and 4 (each within the scatter of the next, the first and the last beyond it). At a limit, above all of these: compound 1.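

Putting 4-chlorophenyl in place of 1H-pyrrol-2-yl gives a measured number rather than a limit in this assay, with an at least 1.6-fold lower number from compound 1 to compound 4 (0.22 log units; that floor lies within the scatter). For the compounds shown here, this is the first exchange of one aromatic ring for another here, and the entering ring has no hydrogen-bond donor, so a donor on this ring is not needed for a measurable number. From the compounds shown here alone, the true size of the step stays unknown because compound 1 stands at a limit: the limit of > 50000 nM in this assay, at which 1 of the 4 values shown sits.

Open, going by these compounds, is whether an amine or a carboxylic acid in place of the chloro of 4-chlorophenyl would lower the number. Also open, on these data alone, is how a 2-furyl ring would compare on the core of compound 1.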